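Swapping the Aryl Group on the Amide Nitrogen of Compound 3

The source may hold more compounds than are shown below. What is called first, only, known or untested is meant among the compounds shown, and "the series" means these compounds.

Of the compounds shown here, three have been measured in a functional assay on A549 cells (Homo sapiens) for cytotoxicity, read by sulforhodamine B assay, with a stated time of 48 h; on this read-out higher numbers stand for weaker inhibition and lower numbers for stronger inhibition. Compound 1 `CO[C@@H]1CC=C2NN(c3ccccn3)C(=O)CC[C@]2(c2ccccc2)O1` gives 1480 nM, compound 2 `CO[C@@H]1CC=C2NN(c3c[nH]c4ccccc34)C(=O)CC[C@]2(c2ccccc2)O1` gives 1110 nM, and compound 3 `CO[C@@H]1CC=C2N(c3ccccn3)C(=O)C[C@]2(c2ccccc2)O1` gives 6110 nM, the highest number of the three and thus the weakest inhibition; its nearest neighbour is compound 1 and its furthest is compound 2, both beyond the scatter. Among the compounds with values here, the only single-change step among them is a 1.3-fold lower number from compound 1 to compound 2 (0.12 log units; within the scatter), a swap of the aromatic group on the amide-type nitrogen that left the number essentially unchanged. Compound 3 differs from compound 1 in the core, not in that group, so for that pair only the two values themselves can be compared.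

Compound 4 `CO[C@@H]1CC=C2N(c3cc(Cl)cc(Cl)c3)C(=O)C[C@]2(c2ccccc2)O1` has not yet been measured. It differs from compound 3 in one place: 3,5-dichlorophenyl in place of pyridin-2-yl on an amide-type nitrogen in a ring. Within the data shown here, the one measured step that bears on it is the swap on the same kind of nitrogen from compound 1 to compound 2, which stayed within the scatter. A step within the scatter is therefore expected here too, with no clear direction. Compound 4 is expected to give about 5000 nM, with a likely range from 1500 nM to 15000 nM. The expected step is a 1.2-fold lower number from compound 3 to compound 4 (0.09 log units; within the scatter).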

Compound 4, half-maximal inhibitory concentration: 7530 nM
Compound 4: middle estimate off by 1.5-fold (0.18 log units), on the low side, within the range that was stated.
By their numbers in this assay, from the lowest: compounds 2 and 1 (each within the scatter of the next); then compounds 3 and 4 (each within the scatter of the next).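

In this assay, putting 3,5-dichlorophenyl in place of pyridin-2-yl on the amide-type nitrogen gives a 1.2-fold higher number from compound 3 to compound 4 (0.09 log units; within the scatter) and so leaves the two compounds indistinguishable in this read-out. Within the data shown here, the earlier swap on this kind of nitrogen was made on the core of compound 1, so this result is the first to show such a swap on the core of compound 3; it also shows that, for this pair, a ring of carbon only carrying two chlorine atoms can replace a ring with one nitrogen and one hydrogen-bond acceptor without a change beyond the scatter. No measurement available here explains why the number holds steady through this exchange.

As far as these compounds go, both groups compared on this core are six-membered aromatic rings, so it remains open whether a non-aromatic group on the same nitrogen, such as a longer alkyl chain, or a group carrying an amine or a carboxylic acid, would shift the number. From the compounds shown here alone, it also remains open whether 3,5-dichlorophenyl would behave the same way on the core of compound 1.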